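A few compounds are considered here, and "the series" means these few. Any claim that something is new, unique, unknown or untested is made for them only; others in the source may bear on it.

Of the compounds shown here, three sharing one core have been measured so far. Compound 1 `Cc1cc(C)cc(Nc2nc(-c3ccncc3)cs2)c1` carries two methyl groups on its outer ring, compound 2 `Fc1cccc(Nc2nc(-c3ccncc3)cs2)c1` a fluorine, and compound 3 `Oc1ccc(Nc2nc(-c3ccncc3)cs2)cc1` a hydroxy group. In a functional assay on RCC4 cells (Homo sapiens) for inhibition, read by XTT assay, with a stated time of 4 days (a higher number here means a weaker inhibitor, a lower number a stronger inhibitor), compound 1 gives 4570 nM, compound 2 gives 40700 nM, and compound 3 gives 5370 nM.

Among these three numbers compound 3 stands second highest. Its nearest neighbour is compound 1, whose number is lower by an amount that lies within the usual scatter of repeated measurements, so the two cannot be told apart. The furthest is compound 2, whose number is higher by an amount that lies beyond the scatter; compound 2 is therefore the weaker inhibitor of that pair.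

The next compound, compound 4 `COc1ccc(Nc2nc(-c3ccncc3)cs2)cc1`, has not yet been measured in this assay. It differs from compound 3 in one place: methyl in place of hydrogen on an oxygen on an aromatic ring. Among the compounds with values here, none of the measured pairs differ by exactly this change, so there is no directly comparable step to lean on.

With that in mind, the step of a 1.3-fold higher number from compound 3 to compound 4 (0.12 log units; within the scatter) is expected to be small, not beyond the scatter. Compound 4 is estimated to give 7000 nM, with a likely range from 2500 nM to 20000 nM.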

Compound 4, half-maximal inhibitory concentration: 14100 nM
Compound 4: the middle estimate sits 2.0-fold (0.30 log units) below what was measured, and the stated range covers the measured number.
By their numbers in this assay, from the lowest: compounds 1 and 3 (each within the scatter of the next); then compound 4; then compound 2.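

Within the data shown here, compound 3 and compound 4 form the first pair in this set that differs in only one place, so this is the first change whose effect can be read directly. Replacing the hydrogen on the oxygen with methyl, which turns hydroxy into methoxy, gives a 2.6-fold higher number from compound 3 to compound 4 (0.42 log units; beyond the scatter) in this assay, making compound 4 the weaker inhibitor of the pair; a single added carbon at this oxygen is therefore enough to shift the result beyond ordinary measurement noise, even though the step is only modest in size. Nothing available here speaks to the reason for this shift.

With only one step at this position, the compounds shown leave open whether the result depends on losing the hydrogen or on adding the methyl, and whether the same change would have a similar effect elsewhere on the outer ring. They also leave open how an amine in place of the hydroxy group, or an ethyl or longer chain on the same oxygen, would compare with compound 3 and compound 4.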